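This account rests on a few compounds, and the source may have more. Where it says the series, first, only, none or still open, it means among the compounds named here.

This account follows the step from compound 1 to compound 3. Among the compounds with values here, compound 1 `CC(C)n1ncc2c(C(=O)Nc3cc(S(N)(=O)=O)ccc3F)cc(-c3cccs3)nc21` is the only member of the set with a measured number in an ADME assay on LLC-MK2 cells (Macaca mulatta) for cytotoxicity, read by spectrophotometry and crystal violet staining, with a stated time of 4 days; on this read-out higher numbers stand for lower toxicity in this test and lower numbers for higher toxicity in this test; there compound 1 gives 25000 nM. Compound 2 `CC(C)n1ncc2c(C(=O)N3CCc4cc(F)ccc43)cc(-c3cccs3)nc21` reaches only a limit in this assay, reported as > 200000 nM, which is the limit of > 200000 nM in this assay, at which 1 of the 2 values shown sits. Compound 3 `CC(C)n1ncc2c(C(=O)Nc3ccccc3F)cc(-c3cccs3)nc21` is not yet measured in this assay. It differs from compound 1 by hydrogen in place of sulfamoyl on an aromatic carbon. No measured step of this kind is shown, so for compound 3 no move beyond the scatter is expected in this assay. Compound 3 is estimated at 30000 nM, with a range from 8000 nM to 120000 nM, meaning an expected step of a 1.2-fold higher number from compound 1 to compound 3 (0.08 log units; within the scatter).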

Compound 3, half-maximal cytotoxic concentration: 50000 nM
For compound 3 the middle estimate is 1.7-fold (0.22 log units) below the measured one; measured number inside the range.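

In this assay, hydrogen in place of sulfamoyl on this aromatic carbon gives a 2.0-fold higher number from compound 1 to compound 3 (0.30 log units; within the scatter). The sulfamoyl group, para to the fluoro group, can therefore be lost here without a step beyond the scatter, so compound 1 and compound 3 cannot be told apart on this read-out. Nothing shown bears on the cause of this step. As far as these compounds go, whether another group on this carbon, such as an amine or a carboxylic acid, would give a step beyond the scatter stays open. So does whether sulfamoyl would behave alike on another carbon of this ring.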